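Isothiocyanate-bearing anilines on a shared core: sulfonamide versus anilide

The source may hold more compounds than are shown below. What is called first, only, known or untested is meant among the compounds shown, and "the series" means these compounds.

Measured so far:
compound 1, `CN(C)C(=O)c1cc2cnc(Nc3ccc(S(=O)(=O)NCCCN=C=S)cc3)nc2n1C1CCCC1`: 41.3%
compound 2, `CN(C)C(=O)c1cc2cnc(Nc3ccc(C(=O)NCCCCCN=C=S)cc3O)nc2n1C1CCCC1`: 22.6%

In a functional assay on NCI-H1299 cells (Homo sapiens) for inhibition, read by CCK-8 assay, with a stated time of 72 h, tested at 1 uM (on this read-out lower numbers stand for a weaker effect and higher numbers for a stronger effect at the one concentration tested), compound 1 gives 41.3%, the higher of the two numbers; compound 2 gives 22.6%, a gap beyond the scatter. Within the data shown here, no pair measured so far differs in one place only, so no single step has been quantified.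

Compound 3, `CN(C)C(=O)c1cc2cnc(Nc3ccc(NC(=O)CCCCN=C=S)cc3)nc2n1C1CCCC1`, is the next compound to be measured. Relative to compound 1 the change is a group of 10 heavy atoms (6 carbon, 2 nitrogen, 1 oxygen, 1 sulfur; no ring) in place of a group of 10 heavy atoms (4 carbon, 2 nitrogen, 2 oxygen, 2 sulfur; no ring), on an aromatic carbon. Nothing among the two measured compounds isolates this kind of change, so the expected step is uncertain; the only other substituent variation on the aniline ring of the shared core (compound 2) came with a lower number. The expectation is therefore a modest downward step, a number 9.3 percentage points lower from compound 1 to compound 3 (within the scatter), which may not exceed the scatter. Compound 3 is estimated to give 32%, within a range from 15% to 50%.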

Compound 3, a percentage reported as inhibition, at one concentration (the size of the read-out at that concentration, not a potency): 58.6%
Compound 3: middle estimate off by 26.6 percentage points, on the low side, and the stated range ends below it.
By their numbers in this assay, from the lowest: compound 2; then compound 1; then compound 3.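

In this assay, replacing the sulfonamide-linked chain with the anilide-linked chain, on an aromatic carbon para to a large group, gives a number 17.3 percentage points higher from compound 1 to compound 3 (beyond the scatter). Among these compounds, this is the first single-place step, and it shows that the read-out at this position responds to the group carrying the isothiocyanate, with both groups at 10 heavy atoms. No accompanying measurement bears on the reason for this step.

The swap alters the linking group and the carbon chain together, so a sulfonamide and an anilide with the same chain would be needed to separate the two. On these data alone, the part played by the isothiocyanate end also remains open, and a primary amine at the end of the chain of compound 3 would address it.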